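Moving the trifluoromethyl on the hydrazone aryl of compound 1

The source may report more compounds than this note shows. Statements on the series, on what has been measured and on what is new or still open speak of the compounds shown alone.

Compound 1 `CN(C(=O)NC(=O)c1cccc(C(F)(F)F)c1)c1nc(C(F)(F)F)c(C(=O)N/N=C/c2ccccc2C(F)(F)F)s1` gives the highest number of the three measured compounds in a functional assay on A549 cells (Homo sapiens) for inhibition, read by MTT assay, with a stated time of 72 h (a higher number here means a weaker inhibitor, a lower number a stronger inhibitor), at 12.1 ug/mL. Compound 2 `CN(C(=O)NC(=O)c1ccccc1F)c1nc(C(F)(F)F)c(C(=O)N/N=C/c2ccccc2C(F)(F)F)s1` gives 6.32 ug/mL in this assay, and compound 3 `CN(C(=O)NC(=O)c1cccc([N+](=O)[O-])c1)c1nc(C(F)(F)F)c(C(=O)N/N=C/c2ccccc2C(F)(F)F)s1` gives 5.45 ug/mL. The change from compound 1 to compound 2 was a 1.9-fold lower number from compound 1 to compound 2 (0.28 log units; within the scatter), the change from compound 1 to compound 3 was a 2.2-fold lower number from compound 1 to compound 3 (0.35 log units; beyond the scatter), and the change from compound 2 to compound 3 was a 1.2-fold lower number from compound 2 to compound 3 (0.06 log units; within the scatter).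

Compound 4 `CN(C(=O)NC(=O)c1cccc(C(F)(F)F)c1)c1nc(C(F)(F)F)c(C(=O)N/N=C/c2cccc(C(F)(F)F)c2)s1` differs from compound 1 only on the hydrazone side: 3-(trifluoromethyl)phenyl in place of 2-(trifluoromethyl)phenyl on a carbon with a double bond to nitrogen. Among the measured compounds shown here, none of the measured steps touches this part of the shared core; all three alter the aryl on the carbonyl carbon, and even there the steps stayed small. For the measured compounds named here, no measured step therefore bears directly on the change, and a step in this assay of no more than the scatter is expected in either direction.

Compound 4 is thus expected to give about 12 ug/mL in this assay, within a range from 5 ug/mL to 30 ug/mL, which corresponds to an expected step of a 1.0-fold lower number from compound 1 to compound 4 (0.00 log units; within the scatter).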

Compound 4, half-maximal inhibitory concentration: 8.16 ug/mL
The estimate for compound 4 lay 1.5-fold (0.17 log units) above the measured number; the range from low to high includes it.
By their numbers in this assay, from the lowest: compounds 3, 2, 4 and 1 (each within the scatter of the next, the first and the last beyond it).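

Among the compounds shown here, compound 4 gives the first reading on the hydrazone side of the shared core, where the earlier steps changed only the aryl on the carbonyl carbon. In this assay there is a 1.5-fold lower number from compound 1 to compound 4 (0.17 log units; within the scatter) when 3-(trifluoromethyl)phenyl replaces 2-(trifluoromethyl)phenyl on a carbon with a double bond to nitrogen, so these two aryl groups cannot be told apart here, at least with the carbonyl aryl of compound 1 in place. No measurement shown accounts for this step.

As far as these compounds go, it remains open whether the same exchange would read alike with the 2-fluorophenyl of compound 2 or the 3-nitrophenyl of compound 3 on the carbonyl carbon. Also open, from the compounds shown here alone, is how an amine or a carboxylic acid in place of the trifluoromethyl on the hydrazone aryl would read in this assay.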